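The source may report more compounds than this note shows. Statements on the series, on what has been measured and on what is new or still open speak of the compounds shown alone.

Measured compounds in a functional assay on SK-BR-3 cells (Homo sapiens) for antiproliferative activity, read by MTT assay, with a stated time of 72 h; a lower number here means a stronger inhibitor, a higher number a weaker inhibitor:
compound 1 `C/C=C1/[C@H](O[C@@H]2O[C@H](CO)[C@@H](O)[C@H](O)[C@H]2O)OC=C(C(=O)OC)[C@H]1CC(=O)OCCc1ccc2c(c1)OCCO2`: > 20000 nM (a limit)
compound 2 `C/C=C1/[C@H](O[C@@H]2O[C@H](CO)[C@@H](O)[C@H](O)[C@H]2O)OC=C(C(=O)OC)[C@H]1CC(=O)OCc1ccc2c(c1)OCCO2`: > 15000 nM (a limit)
compound 3 `C/C=C1/[C@H](O[C@@H]2O[C@H](CO)[C@@H](O)[C@H](O)[C@H]2O)OC=C(C(=O)OC)[C@H]1CC(=O)OCCc1ccc(OC)c(OC)c1`: > 15000 nM (a limit)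

The three measured compounds share one core and differ only in the ester group on the chain. None of them gives a number in this assay. Compound 1 reaches only a limit, > 20000 nM. Compound 2 likewise reaches only a limit, > 15000 nM. Compound 3 stands at a limit as well, > 15000 nM, and so its position relative to the other two cannot be placed: the steps a step that the two limits leave unreadable from compound 1 to compound 2, a step that the two limits leave unreadable from compound 1 to compound 3 and a step that the two limits leave unreadable from compound 2 to compound 3 are all unreadable, since each rests on two limits (the limit of > 15000 nM in this assay, at which 2 of the 3 values shown sit, (the limit of > 20000 nM in this assay, at which 1 of the 3 values shown sits)).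

The next compound is compound 4 `C/C=C1/[C@H](O[C@@H]2O[C@H](CO)[C@@H](O)[C@H](O)[C@H]2O)OC=C(C(=O)OC)[C@H]1CC(=O)OC`. It differs from compound 3 by hydrogen in place of 3,4-dimethoxybenzyl on a saturated chain carbon bound to an oxygen next to a carbonyl group. For the measured compounds named here, no measured step bears on this change in a readable way; every step among compounds 1, 2 and 3 is a step between limits, so no size or direction can be drawn from them. With three ester variants of this core all failing to reach a number, the expectation for the smaller ester of compound 4 is that it too will most likely sit at a limit; the expected step is a step that the limit leaves unreadable from compound 3 to compound 4. Compound 4 is therefore estimated at 30000 nM, with a range from 8000 nM to 100000 nM.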

Compound 4, half-maximal inhibitory concentration: > 15000 nM
Compound 4 ended at the assay's limit (the forecaster's own chance of this, stated with the estimate: 80%); the middle value does not contradict the limit.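

In this assay compound 4 gives > 15000 nM, which is a limit. No step linking compound 4 to compound 1, compound 2 or compound 3 can be read, since each pair rests on two limits: the limit of > 15000 nM in this assay, at which 3 of the 4 values shown sit.

Still open, on these data alone, is whether any ester on the shared core reaches a measurable value in this assay, and how these four compounds rank.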